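Series notes: chloro to methyl on the phenoxy ring

The source may hold more compounds than are shown below. What is called first, only, known or untested is meant among the compounds shown, and "the series" means these compounds.

All three measured compounds were read in an ADME assay on MT4 cells (Homo sapiens) for cytotoxicity, read by MTT assay, with a stated time of 4 days; a higher number here means that more compound is tolerated, a lower number that less compound is tolerated:

compound 1, `COc1cc(C#N)cc(OC)c1Oc1nc(Nc2ccc(C#N)cc2)nc2ccccc12`, gives 194000 nM
compound 2, `N#Cc1ccc(Nc2nc(Oc3ccccc3Cl)c3ccccc3n2)cc1`, gives 38000 nM
compound 3, `CCCOc1cc(C#N)cc(OCC)c1Oc1nc(Nc2ccc(C#N)cc2)nc2ccccc12`, gives 123000 nM

Compound 2 stands lowest of the three numbers in this assay. The nearest to it is compound 3, whose number is higher by a gap beyond the scatter; compound 1 lies further still, also beyond the scatter. Neither pair is a single-point change, so only the bare values are stated for them.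

Compound 4, `Cc1ccccc1Oc1nc(Nc2ccc(C#N)cc2)nc2ccccc12`, is not yet measured in this assay. It differs from compound 2 by methyl in place of chloro on an aromatic carbon. Chloro leaves and methyl enters, each a single heavy atom, neither with ring, donor, acceptor or charge, placed on an aromatic carbon of a six-membered aromatic ring of carbon only, ortho to a large group.

Within the data shown here, no measured pair in this set isolates this change, so the expectation rests on compound 2 alone. The step from compound 2 to compound 4 is expected to be small, a 1.2-fold higher number from compound 2 to compound 4 (0.07 log units; within the scatter), in either direction and not beyond the scatter. Compound 4 is estimated at 45000 nM, within a range from 18000 nM to 110000 nM.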

Compound 4, half-maximal cytotoxic concentration: 355000 nM
For compound 4 the middle estimate is 7.9-fold (0.90 log units) below the measured one, and the stated range ends below it.
By their numbers in this assay, from the lowest: compound 2; then compounds 3, 1 and 4 (each within the scatter of the next, the first and the last beyond it).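

In this assay, among these compounds, the change from 2-chlorophenoxy to 2-methylphenoxy gives a 9.3-fold higher number from compound 2 to compound 4 (0.97 log units; beyond the scatter), and this is the first comparison that isolates a single place. It shows that this aromatic carbon, ortho to a large group, is not a silent position in this read-out: exchanging one single heavy atom for another moves the number beyond the scatter, although neither group brings a ring, a hydrogen-bond donor, a hydrogen-bond acceptor or a charge. Nothing measured here accounts for the size of this step.

On these data alone, how far this position responds beyond these two groups remains open, since a fluoro, a methoxy, an amine or a longer chain such as propyl at the same carbon could show whether the step follows a trend or is particular to chloro and methyl. Compound 1 and compound 3 differ from compound 4 in more than one place, so the same exchange on their more heavily substituted rings remains an untested question, and their values cannot be set against this step.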